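The source may hold more compounds than are shown below. What is called first, only, known or untested is meant among the compounds shown, and "the series" means these compounds.

For the measured compounds named here, in an assay on CHO cells for displacement of a labelled ligand from adenosine receptor A3 (Homo sapiens), read by scintillation counting, with a stated time of 60 min (a lower number here means a stronger inhibitor, a higher number a weaker inhibitor), compound 1 `COc1cccc(CCC(=O)Nc2nc3ccccc3c(=O)s2)c1` gives 173 nM, the only number reported for this set. Compound 2 `COc1cccc(/C=C/C(=O)Nc2nc3ccccc3c(=O)s2)c1` returns > 1000 nM, which is a limit of the assay and not a number; that reading sits at the limit of > 1000 nM in this assay, at which 1 of the 2 values shown sits. Compound 3 `O=C(CCCc1cccc(Cl)c1)Nc1nc2ccccc2c(=O)s1` differs from compound 1 by 3-chlorobenzyl in place of 3-methoxyphenyl on a saturated chain carbon, two bonds along the chain from a carbonyl carbon. Going by the values given here, no measured step covers such a change, so only a modest shift is expected, a step of a 1.4-fold higher number from compound 1 to compound 3 (0.16 log units; within the scatter) that need not pass beyond the scatter. Compound 3 is accordingly estimated at 250 nM, within 80 nM to 800 nM.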

Compound 3, inhibition constant: > 1000 nM
Compound 3: no number, only a limit; the forecaster's own chance of this, stated with the estimate: 20%; middle value at least 4.0-fold (0.60 log units) away from the limit.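

In this assay, 3-chlorobenzyl in place of 3-methoxyphenyl on a saturated chain carbon, two bonds along the chain from a carbonyl carbon, gives an at least 5.7-fold higher number from compound 1 to compound 3 (0.76 log units; beyond the scatter), so this position does not tolerate every group of this size. The reading for compound 3 is a limit of the assay and not a number, so the full size of the step stays unknown: the limit of > 1000 nM in this assay, at which 2 of the 3 values shown sit.

The compounds shown do not separate the chlorine from the added benzyl carbon. As far as these compounds go, how a 3-chlorophenyl, an amine or a carboxylic acid would read at this position remains open.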